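This account rests on a few compounds, and the source may have more. Where it says the series, first, only, none or still open, it means among the compounds named here.

Working notes on the series. In an assay on Sf9 cells for inhibition of mitogen-activated protein kinase kinase kinase 14 variant S549D (Homo sapiens), with a stated time of 30 min, in the presence of a further agent that is not named here (on this read-out lower numbers stand for stronger inhibition and higher numbers for weaker inhibition), compound 1 `C#Cc1ccc2ncn(-c3ccnc(N)n3)c2c1` gives 251 nM, the lowest of the two numbers in hand. Among the measured compounds shown here, compound 2 `C=CC(=O)NCCCc1ccc2ncn(-c3ccnc(N)n3)c2c1` gives 501000 nM in this assay, and the only measured step, a 2000-fold higher number from compound 1 to compound 2 (3.30 log units; beyond the scatter), removes the ethynyl altogether and puts 3-((vinylcarbonyl)amino)propyl in its place. Compound 3 `C=Cc1cc(C#Cc2ccc3ncn(-c4ccnc(N)n4)c3c2)ccn1` keeps the ethynyl of compound 1 and caps it: 2-vinylpyridin-4-yl in place of hydrogen on a triple-bonded carbon. For the measured compounds named here, the step from compound 1 to compound 2 bears only loosely on this, since there the ethynyl leaves and here it stays; no measured step extends the ethynyl of compound 1. The number for compound 3 in this assay is therefore estimated near that of compound 1, with a step of a 1.2-fold higher number from compound 1 to compound 3 (0.08 log units; within the scatter) that may fall within the scatter in either direction, and the range is kept wide. Compound 3 is expected at 300 nM, between 40 nM and 2500 nM.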

Compound 3, half-maximal inhibitory concentration: 20000 nM
Compound 3: middle estimate off by 67-fold (1.82 log units), on the low side; measured number above the stated range.
By their numbers in this assay, from the lowest: compound 1; then compound 3; then compound 2.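

Replacing hydrogen with 2-vinylpyridin-4-yl on the triple-bonded carbon gives an 80-fold higher number from compound 1 to compound 3 (1.90 log units; beyond the scatter) in this assay, so this position does not accept every extension of the ethynyl. Keeping the ethynyl therefore does not by itself keep the number near that of compound 1, which the earlier step could not show, since the ethynyl leaves there. The data at hand give no explanation for the rise.

From the compounds shown here alone, whether a methyl or an unsubstituted phenyl on the same triple-bonded carbon would stay close to compound 1 or rise as far as compound 3 remains open. Also open is which part of the entering group accounts for the rise: its six-membered aromatic ring, or its double bond outside that ring.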